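Chain extension on the amine nitrogen: half-life outlook

The source may hold more compounds than are shown below. What is called first, only, known or untested is meant among the compounds shown, and "the series" means these compounds.

Compound 3 `CC(C)N1C(=O)C(=O)N=C1/N=C(\NCC(C)(C)C)Nc1ccc(Cl)c(Cl)c1` stands at a limit of an in vitro ADME assay on microsomes from liver (Homo sapiens) for metabolic stability, read by LC-MS (on this read-out higher numbers stand for a longer-lived compound and lower numbers for a shorter-lived compound), reported as > 1 h, which is a limit and not a number. Compound 1 `CCON/C(=N\C1=NC(=O)C(=O)N1C(C)C)Nc1ccc(Cl)c(Cl)c1` likewise gives a limit there, > 1 h. Compound 2 `CC(C)N/C(=N\C1=NC(=O)C(=O)N1C(C)C)Nc1ccc(Cl)c(Cl)c1` also returns a limit, > 1 h. The steps a step that the two limits leave unreadable from compound 1 to compound 2, a step that the two limits leave unreadable from compound 1 to compound 3 and a step that the two limits leave unreadable from compound 2 to compound 3 are accordingly unreadable, all three values resting at the limit of > 1 h in this assay, at which 3 of the 3 values shown sit. Compound 4 `CCCCCCN/C(=N\C1=NC(=O)C(=O)N1C(C)C)Nc1ccc(Cl)c(Cl)c1` differs from compound 3 by pentyl in place of tert-butyl on a saturated chain carbon bound to an amine nitrogen. Among the measured compounds shown here, no measured step bears readably on this change, since every comparison among compounds 1, 2 and 3 ends at the limit. The step that the limit leaves unreadable from compound 3 to compound 4 is therefore expected to show nothing beyond the scatter. Compound 4 is estimated at 1.5 h, within 0.5 h to 4 h, most likely reported again only as a limit.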

Compound 4, half-life: 0.131 h
For compound 4 the middle estimate is 11-fold (1.06 log units) above the measured one; measured number outside the range, below it.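

In this assay the hexyl chain gives the only true number among the compounds shown, so a change at this position on the amine nitrogen can now be read as an at least 7.6-fold lower number from compound 3 to compound 4 (0.88 log units; beyond the scatter). Hexyl in place of isopropyl reads as an at least 7.6-fold lower number from compound 2 to compound 4 (0.88 log units; beyond the scatter), and hexyl in place of ethoxy reads as an at least 7.6-fold lower number from compound 1 to compound 4 (0.88 log units; beyond the scatter). Compounds 1, 2 and 3 each stay at a limit, and the steps among them cannot be read: the limit of > 1 h in this assay, at which 3 of the 4 values shown sit.

A butyl chain or a branched hexyl chain could separate the effect of chain length from that of branching. From the compounds shown here alone, how far compounds 1, 2 and 3 lie beyond their limit stays open.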